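The compounds below may be only part of what the source reports. "The series", "measured", "known", "first", "only" and "open" are said of these compounds alone.

Compound 1 `Nc1ccc(Nc2nc3ccccc3nc2S(=O)(=O)c2ccccc2)cc1` gives 8720 nM in a functional assay on HL-60 cells (Homo sapiens) for cytotoxicity, read by MTT assay, with a stated time of 72 h; on this read-out lower numbers stand for stronger inhibition and higher numbers for weaker inhibition. Compound 2 `COc1cc(Nc2nc3ccccc3nc2S(=O)(=O)c2ccc(C)cc2)cc(OC)c1` gives 20 nM in this assay. Compound 3 `COc1cc(Nc2nc3ccccc3nc2S(=O)(=O)c2ccc(C)cc2)cc(OC)c1OC` gives 320 nM in this assay.

Compound 3 stands second highest of the three numbers. Its nearest neighbour is compound 2, reached by a 16-fold higher number from compound 2 to compound 3 (1.20 log units; beyond the scatter). Among the compounds with values here, compound 1 lies furthest away with a far higher number, but its structure differs in more than one place and no single step joins the two.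

Compound 4 `COc1ccc(S(=O)(=O)c2nc3ccccc3nc2Nc2cc(OC)c(OC)c(OC)c2)cc1` differs from compound 3 by methoxy in place of methyl on an aromatic carbon. Within the data shown here, no measured step bears on this place; the one known step, a 16-fold higher number from compound 2 to compound 3 (1.20 log units; beyond the scatter), sits on the other aromatic ring. With nothing to point either way, no change beyond the scatter is expected. Compound 4 is therefore estimated at 320 nM, within 100 nM to 1000 nM. This estimate means an expected step of no change at the digits printed from compound 3 to compound 4 (within the scatter).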

Compound 4, half-maximal inhibitory concentration: 680 nM
Beside the measured number, compound 4's estimate is 2.1-fold (0.33 log units) below it; the measured number falls inside the stated range.
By their numbers in this assay, from the lowest: compound 2; then compound 3; then compound 4; then compound 1.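

Moving from (4-methylphenyl)sulfonyl to (4-methoxyphenyl)sulfonyl gives a 2.1-fold higher number from compound 3 to compound 4 (0.33 log units; beyond the scatter) in this assay, so this position, which no earlier step had touched, does respond to the change, though modestly. That step is smaller than a 16-fold higher number from compound 2 to compound 3 (1.20 log units; beyond the scatter) on the other aromatic ring. Nothing shown accounts for the shift. The compounds shown leave open how an amine or a carboxylic acid would fare at this position. They also leave open whether the same change would give a similar step with the other aromatic ring as in compound 2.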